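Methoxy in place of acetamido on a series

The source may hold more compounds than are shown below. What is called first, only, known or untested is meant among the compounds shown, and "the series" means these compounds.

Working notes on a small set sharing one core. Among the measured compounds shown here, compound 1 `COc1nn(Cc2ccccc2N)c(=O)o1` is the only member with a number so far: in an assay on COS-7 cells for inhibition of Fatty-acid amide hydrolase 1 (Homo sapiens), read by scintillation counting, with a stated time of 10 min, tested at 10 uM (on this read-out lower numbers stand for less inhibition and higher numbers for more inhibition at the one concentration tested (going by the name of the read-out)), compound 1 gives 8%, a small read-out at the single concentration tested. Compound 2 `COc1nn(Cc2cccc(NC(C)=O)c2)c(=O)o1` carries acetamido on the six-membered aromatic ring of carbon only; in this assay compound 2 gives "not active" (no number reported), so no number stands for it and it cannot be placed against compound 1 by a value. Compound 3 `COc1cccc(Cn2nc(OC)oc2=O)c1` has not been tested. Its relation to compound 2 is methoxy in place of acetamido on an aromatic carbon. For the measured compounds named here, no step between measured compounds exists, so nothing in the set tells how a change at this place moves the read-out. Given that compound 1 gives 8% and compound 2 gives "not active" (no number reported), any step to compound 3 in this assay is expected to stay within the scatter, with no clear direction, and a low read-out is expected. Compound 3 is therefore estimated at 5%, with a range from 0% to 15%, and a fair chance that only "not active" is reported.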

Compound 3, a percentage reported as inhibition, at one concentration (the size of the read-out at that concentration, not a potency): "not active" (no number reported)
The entry for compound 3 holds no number, so the estimate cannot be set against anything.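

Compound 2 and compound 3 both stand without a number, so no step can be read between them. The compounds shown leave open how methoxy in place of acetamido moves the read-out, and how either compound stands against compound 1 at 8% in terms of size. No evidence bears on this result.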